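The source may hold more compounds than are shown below. What is called first, only, known or untested is meant among the compounds shown, and "the series" means these compounds.

Three esters of the shared core have been measured in an assay on NIH3T3 cells with Urotensin-2 receptor (Homo sapiens) as the target; on this read-out lower numbers stand for an effect already at smaller amounts and higher numbers for an effect only at larger amounts of compound. Compound 1 `CCc1ccccc1C(=O)OC(CCN(C)C)c1ccc(Cl)cc1` gives 1290 nM in this assay. Compound 2 `Cc1cccc(C(=O)OC(CCN(C)C)c2ccc(Cl)cc2)c1C` gives 1150 nM, and compound 3 `Cc1c(Cl)cccc1C(=O)OC(CCN(C)C)c1ccc(Cl)cc1` gives 1120 nM. Compound 3 carries the lowest of the three numbers, yet compound 2 and compound 1 both sit within the scatter of it, so no ranking among the three is established. The steps of a 1.1-fold lower number from compound 1 to compound 2 (0.05 log units; within the scatter) and a 1.2-fold lower number from compound 1 to compound 3 (0.06 log units; within the scatter) exchange one substituted phenyl on the carbonyl carbon for another, and a 1.0-fold lower number from compound 2 to compound 3 (0.01 log units; within the scatter) exchanges a single substituent on that ring; none of them left the scatter. Compound 4 `Cc1ccc(C)c(C(=O)OC(CCN(C)C)c2ccc(Cl)cc2)c1` differs from compound 3 in just this kind of way: 2,5-dimethylphenyl in place of 3-chloro-2-methylphenyl on a carbonyl carbon. All three measured exchanges of the aryl pattern at this position bear on it, and all were flat. On this basis compound 4 is expected to show a step of a 1.0-fold higher number from compound 3 to compound 4 (0.01 log units; within the scatter) in this assay, nothing beyond the scatter. Compound 4 is therefore estimated at 1150 nM in this assay, with a range from 600 nM to 2300 nM.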

Compound 4, half-maximal effective concentration: 1860 nM
Beside the measured number, compound 4's estimate is 1.6-fold (0.21 log units) below it; the measured number falls inside the stated range.
By their numbers in this assay, from the lowest: compounds 3, 2, 1 and 4 (each within the scatter of the next).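

With 2,5-dimethylphenyl on the carbonyl carbon, this assay shows a 1.7-fold higher number from compound 3 to compound 4 (0.22 log units; within the scatter) and a 1.6-fold higher number from compound 2 to compound 4 (0.21 log units; within the scatter) and a 1.4-fold higher number from compound 1 to compound 4 (0.16 log units; within the scatter) and all three stay within the scatter. The flat picture that rested on 2-ethylphenyl, 2,3-dimethylphenyl and 3-chloro-2-methylphenyl therefore holds for a fourth aryl pattern, although these steps are wider than the earlier ones. Nothing at hand speaks to why these steps are wider.

Every ring shown carries only alkyl or chloro substituents, so the compounds leave open whether a methoxy group, an amine or a carboxylic acid on this ring would give a step beyond the scatter. Among these compounds, also open is whether a longer chain in place of the one carrying the dimethylamino group would do so.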